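Working notes on the series, step from compound 1 to 4

The source may report more compounds than this note shows. Statements on the series, on what has been measured and on what is new or still open speak of the compounds shown alone.

compound 1 `C/N=C(/NC#N)NCCCn1nc(-c2ccccc2)ccc1=O`: > 100 mg/kg
compound 2 `CC/N=C(/NC#N)NCCCn1nc(C)ccc1=O`: > 100 mg/kg
compound 3 `C/N=C(/NC#N)NCCCCn1nc(-c2ccc(Cl)cc2)ccc1=O`: 100 mg/kg

In a functional assay on the whole organism (stomach) with Rattus norvegicus as the target (a higher number here means that more compound is needed for the effect, a lower number that less compound is needed), compound 1 gives > 100 mg/kg, which is a limit of the assay and not a number. Compound 2 likewise gives only a limit, > 100 mg/kg. Compound 3 gives 100 mg/kg. Among the compounds with values here, compound 1 therefore stands at the limit of > 100 mg/kg in this assay, at which 2 of the 3 values shown sit, so its true dose is unknown and no measured step anchors the series.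

Compound 4 `N#CNC(=N)NCCCCn1nc(-c2ccccc2)ccc1=O` differs from compound 1 by a group of 7 heavy atoms (3 carbon, 4 nitrogen; no ring) in place of a group of 7 heavy atoms (3 carbon, 4 nitrogen; no ring), on a saturated chain carbon, three bonds along the chain from an aromatic nitrogen. With no measured step between the three compounds shown, and all values at or near the same dose, no change beyond the scatter is expected: the step is estimated as a number no higher from compound 1 to compound 4 (the limit leaves the size open). For compound 4 the expected value is 100 mg/kg, in the range 30 mg/kg to 300 mg/kg, with a fair chance that only a limit is reported.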

Compound 4, dose for half-maximal effect: 77.2 mg/kg
Beside the measured number, compound 4's estimate is 1.3-fold (0.11 log units) above it, and the stated range covers the measured number.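

Within the data shown here, at this position, on a saturated chain carbon, three bonds along the chain from an aromatic nitrogen, exchanging one group for another with the same atoms joined differently gives the first readable step in this assay: an at least 1.2-fold lower number from compound 1 to compound 4 (0.11 log units; that floor lies within the scatter). Compound 4, with 3 hydrogen-bond donors in the entering group in place of 2, gives a measured number of 77.2 mg/kg. The true size of the step stays open since compound 1 has only a limit: the limit of > 100 mg/kg in this assay, at which 2 of the 4 values shown sit.

As far as these compounds go, whether an amine or a carboxylic acid at this place would move the dose beyond the scatter remains open. So does the effect of a longer chain.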